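Swapping the phenyl of compound 1 for an amine chain

This account rests on a few compounds, and the source may have more. Where it says the series, first, only, none or still open, it means among the compounds named here.

Compound 1 `Nc1nn2c(O)cc(-c3ccccc3)nc2c1[N+](=O)[O-]` gives > 100 ug/mL in an ADME assay (Homo sapiens) for cytotoxicity (on this read-out higher numbers stand for lower toxicity in this test and lower numbers for higher toxicity in this test), which is a limit of the assay rather than a number.
Compound 2 `Nc1nn2c(O)cc(CNNCCO)nc2c1[N+](=O)[O-]` gives > 50 ug/mL in this assay, again only a limit of the assay.

So compound 1 stands at a limit, and the one other value shown is a limit too. Going by the values given here, the only measured step is a step that the two limits leave unreadable from compound 1 to compound 2, which cannot be read because the limit of > 100 ug/mL in this assay, at which 1 of the 2 values shown sits, and the limit of > 50 ug/mL in this assay, at which 1 of the 2 values shown sits, are both limits, so no size and no direction can be taken from it. The change to the new compound is of the same kind: compound 3 `CCSC(N)NCc1cc(O)n2nc(N)c([N+](=O)[O-])c2n1` differs from compound 1 by ((amino(ethylsulfanyl)methyl)amino)methyl in place of phenyl on an aromatic carbon. With nothing measurable to build on, no shift beyond the usual scatter is expected. Compound 3 is estimated at 100 ug/mL, with a range from 30 ug/mL to 300 ug/mL. This estimate means an expected step of a number no higher from compound 1 to compound 3 (the limit leaves the size open), most likely reported again only as a limit.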

Compound 3, half-maximal cytotoxic concentration: > 50 ug/mL
Compound 3 was reported as a limit; the forecaster's own chance of this, stated with the estimate: 70%; the middle value lies beyond the limit too.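

Compound 3 gives > 50 ug/mL in this assay, which is again only a limit. Its steps from compound 1 and from compound 2 cannot be read: all three values are limits. The compounds shown leave open at what concentration any of them becomes cytotoxic, and whether phenyl and the two amine chains differ at all.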